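The source may report more compounds than this note shows. Statements on the series, on what has been measured and on what is new or still open speak of the compounds shown alone.

Compound 1 `Cc1c2c(n3c1CCN(C(=O)CN)C[C@@H](C)[C@H](C)Nc1cc-3ccc1C(N)=O)CC(C)(C)CC2=O`: 190 nM
Compound 2 `CC[C@H](N)C(=O)N1CCc2c(C)c3c(n2-c2ccc(C(N)=O)c(c2)N[C@@H](C)[C@H](C)C1)CC(C)(C)CC3=O`: 41 nM

In a functional assay on NCI-H1975 cells (Homo sapiens) for antiproliferative activity (a lower number here means a stronger inhibitor, a higher number a weaker inhibitor), compound 2 has the lower of the two numbers, at 41 nM. Compound 3 `Cc1c2c(n3c1CCN(C(=O)C(C)(C)N)C[C@@H](C)[C@H](C)Nc1cc-3ccc1C(N)=O)CC(C)(C)CC2=O` has 1-amino-1-methylethyl in place of 1-aminopropyl on a carbonyl carbon. Going by the values given here, only one measured step bears on this change, a 4.6-fold lower number from compound 1 to compound 2 (0.67 log units; beyond the scatter), and it swapped hydrogen for ethyl. Among the compounds with values here, compound 3 keeps the same atoms as compound 2, joined differently, and no measured pair shows this exact swap. A smaller step than that one is therefore expected, tilted towards a higher number in this assay. The expected change is a 1.5-fold higher number from compound 2 to compound 3 (0.17 log units; within the scatter). Compound 3 is estimated at 60 nM, with an expected range of 20 nM to 180 nM.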

Compound 3, half-maximal inhibitory concentration: 21 nM
For compound 3 the middle estimate is 2.9-fold (0.46 log units) above the measured one; the measured number falls inside the stated range.
By their numbers in this assay, from the lowest: compounds 3 and 2 (each within the scatter of the next); then compound 1.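

In this assay replacing 1-aminopropyl with 1-amino-1-methylethyl on the carbonyl carbon gives a 2.0-fold lower number from compound 2 to compound 3 (0.29 log units; within the scatter) and so cannot be told apart from the scatter of repeated measurements. The entering group, which has no defined stereocentre, still gives a 9.0-fold lower number from compound 1 to compound 3 (0.96 log units; beyond the scatter) when set against aminomethyl, a step beyond the scatter. No measured evidence explains either step. Still open, going by these compounds, is how a longer chain such as 1-aminobutyl or a ring such as 1-aminocyclopropyl would fare here. A hydroxyl in place of the amine also remains to be compared.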